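One Ring Swapped on a Shared Core

A few compounds are considered here, and "the series" means these few. Any claim that something is new, unique, unknown or untested is made for them only; others in the source may bear on it.

Measured so far:
compound 1 `Cc1n[nH]c(-c2ccccc2NCC2=NCCN2)n1`: < 5020 nM
compound 2 `Cc1nc(-c2ccccc2NCC2=NCCN2)n(C)n1`: < 5020 nM
compound 3 `CCn1cc(-c2ccccc2NCC2=NCCN2)cn1`: < 100000 nM

All three values come from an in vitro functional assay on cells (Fibroblast) for agonist activity at Alpha-1B adrenergic receptor (Homo sapiens); on this read-out lower numbers stand for an effect already at smaller amounts and higher numbers for an effect only at larger amounts of compound. For compound 1 the value < 5020 nM is a limit of the assay and not a measured number (the limit of < 5020 nM in this assay, at which 2 of the 3 values shown sit). Compound 2 also stops at a limit with < 5020 nM. Compound 3 stops at a different limit with < 100000 nM (the limit of < 100000 nM in this assay, at which 1 of the 3 values shown sits). Every value shown is a limit, so compound 1 cannot be placed relative to the others, and the step that the two limits leave unreadable from compound 1 to compound 2 stays unreadable for the same reason.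

Compound 4 `Cn1cccc1-c1ccccc1NCC1=NCCN1` differs from compound 1 by 1-methyl-1H-pyrrol-2-yl in place of 3-methyl-1H-1,2,4-triazol-5-yl on an aromatic carbon. Going by the values given here, no measured step covers this exchange, and the limits give no direction to read from. The expected step is therefore a step that the limit leaves unreadable from compound 1 to compound 4, a change that is not expected to stand out beyond the scatter. On that basis compound 4 is estimated at 1500 nM, with a range from 150 nM to 15000 nM.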

Compound 4, half-maximal effective concentration: < 100000 nM
Compound 4 gave a limit, no number (the forecaster's own chance of this, stated with the estimate: 50%); the middle value is on the limit's open side.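

Compound 4 gives < 100000 nM, which is a limit of the assay and not a number. Compound 1 also stands at a limit, so the step between compound 1 and compound 4 cannot be read. Going by these compounds, whether exchanging this ring on the shared core shifts the result in this assay at all, and in which direction, stays open.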